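The compounds below may be only part of what the source reports. "The series", "measured", "known", "first", "only" and "open" are said of these compounds alone.

Values so far in an ADME assay on MT4 cells (Homo sapiens) for cytotoxicity, read by MTT assay, with a stated time of 96 h; on this read-out lower numbers stand for higher toxicity in this test and higher numbers for lower toxicity in this test:
Compound 1 `CC(=O)c1ccc2c(c1)nc(-c1ccccc1)n2C1CCCCC1`: 37000 nM
Compound 2 `CC(=O)c1ccc2c(c1)nc(-c1ccoc1)n2C1CCCCC1`: 63000 nM

Among the compounds with values here, compound 2 cannot be ranked against compound 1, since the only measured step, a 1.7-fold higher number from compound 1 to compound 2 (0.23 log units; within the scatter), lies within the scatter. The next compound is compound 3 `CC(=O)c1ccc2c(c1)nc(-c1ccccn1)n2C1CCCCC1`. The change is pyridin-2-yl in place of furan-3-yl on an aromatic carbon, at the place next to the ring atom that bears a cyclohexyl group. Within the data shown here, the single measured step was made at this same place, so it is the only guide. Like compound 1 with its phenyl, compound 3 carries a six-membered aromatic ring here, but no pyridin-2-yl group has been measured yet, and one step shows no trend. In this assay, no step beyond the scatter is expected, given that the exchange of phenyl for furan-3-yl gave only a 1.7-fold higher number from compound 1 to compound 2 (0.23 log units; within the scatter). The expected change is a 1.3-fold lower number from compound 2 to compound 3 (0.10 log units; within the scatter), an estimate. For compound 3 the estimated value is 50000 nM, with an expected range of 22000 nM to 100000 nM.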

Compound 3, half-maximal cytotoxic concentration: 70000 nM
Estimate against measurement, compound 3: 1.4-fold (0.15 log units) below; the range from low to high includes it.
By their numbers in this assay, from the lowest: compounds 1, 2 and 3 (each within the scatter of the next).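

At the aromatic carbon between two ring nitrogen atoms, next to the ring atom that bears a cyclohexyl group, this assay now covers three aromatic rings: pyridin-2-yl against furan-3-yl gives a 1.1-fold higher number from compound 2 to compound 3 (0.05 log units; within the scatter), and pyridin-2-yl against phenyl gives a 1.9-fold higher number from compound 1 to compound 3 (0.28 log units; within the scatter). A six-membered aromatic ring with 1 hetero atom, a six-membered aromatic ring without one and a five-membered aromatic ring with 1 hetero atom therefore all lie within the scatter of one another at this place, so neither ring size nor the ring nitrogen can be read as a separate step among compounds 1, 2 and 3. No measurement at hand offers an explanation for this reading.

Still open, going by these compounds, is whether an amine, a carboxylic acid or a longer alkyl chain at this place would give a step beyond the scatter, and whether a substituent on the pyridin-2-yl ring would do so. Also open is the contribution of the cyclohexyl group and the acetyl group, since all the compounds shown carry both unchanged.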